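Removing the methylsulfanyl group from a weak selenium quinazoline

A few compounds are considered here, and "the series" means these few. Any claim that something is new, unique, unknown or untested is made for them only; others in the source may bear on it.

Within the data shown here, compound 1 `CCCCC[Se]c1nc(NCc2ccc(SC)cc2)c2ccccc2n1` is the only member of this small set that returns an actual number in a functional assay on MCF7 cells (Homo sapiens) for cytotoxicity, read by MTT assay, with a stated time of 72 h (a higher number here means a weaker inhibitor of growth, a lower number a stronger inhibitor of growth), where compound 1 gives 65000 nM. Compound 2 `[SeH]c1nc(NCc2ccccc2)c2cccnc2n1` reaches only a limit of the assay; in this assay compound 2 gives > 100000 nM. Compound 3 `CSc1ccc(CNc2nc([SeH])nc3ccccc23)cc1` likewise sits at a limit, and in this assay compound 3 gives > 100000 nM. Among the measured compounds shown here, the one measured step, an at least 1.5-fold higher number from compound 1 to compound 3 (0.18 log units; that floor lies within the scatter), shows that hydrogen in place of pentyl on the selenium did not make the compound stronger. Compound 4 `CCCCC[Se]c1nc(NCc2ccccc2)c2ccccc2n1` differs from compound 1 in another place: hydrogen in place of methylsulfanyl on an aromatic carbon. For the measured compounds named here, no measured pair isolates this change, so the account can only note the limit of > 100000 nM in this assay, at which 2 of the 3 values shown sit, as the setting into which compound 4 is likely to fall. A step of a 1.4-fold higher number from compound 1 to compound 4 (0.14 log units; within the scatter) is therefore expected, with weakening more probable than gain. Compound 4 is estimated at 90000 nM, within 40000 nM to 200000 nM.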

Compound 4, concentration for total growth inhibition: 47100 nM
Estimate against measurement, compound 4: 1.9-fold (0.28 log units) above; the measured number falls inside the stated range.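

In this assay, the step at this position, a 1.4-fold lower number from compound 1 to compound 4 (0.14 log units; within the scatter), shows that exchanging methylsulfanyl for hydrogen on the aromatic carbon para to a large group gives no readable change. The earlier compounds shown here could not show whether a number depended on the methylsulfanyl group, but with hydrogen at this position and the pentyl on selenium kept, compound 4 still returns an actual number and not a limit. The two values that remain limits of the assay belong to other compounds in the set: the limit of > 100000 nM in this assay, at which 2 of the 4 values shown sit.

The compounds shown leave open whether another group at this position, such as an amine, a carboxylic acid or a methoxy group, would give a step beyond the scatter. They also leave open whether a longer chain on selenium would do so on the core of compound 4.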